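A Stereocentre Flip on a Weakly Cytotoxic Core

The source may report more compounds than this note shows. Statements on the series, on what has been measured and on what is new or still open speak of the compounds shown alone.

Compound 1 `CC(=O)OC[C@H]1O[C@H](NS(=O)(=O)c2ccc(C)cc2)C=C[C@H]1OC(C)=O`: in a functional assay on A549 cells (Homo sapiens) for cytotoxicity, read by MTT assay, with a stated time of 24 h (a lower number here means a stronger inhibitor, a higher number a weaker inhibitor), compound 1 gives > 1000000000 nM, which is a limit of the assay and not a number.
Compound 2 `CC(=O)OC[C@H]1O[C@H](NS(N)(=O)=O)C=C[C@H]1OC(C)=O`: in this assay compound 2 gives 558000000 nM.
Compound 3 `CCS(=O)(=O)N[C@@H]1C=C[C@H](OC(C)=O)[C@@H](COC(C)=O)O1`: in this assay compound 3 gives 280000000 nM.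

All three compounds share a core and differ at the group on the sulfonyl sulfur. Compound 3 and compound 2 give numbers that sit within the usual scatter of one another, so neither can be called the stronger inhibitor. Compound 1 sits at a limit of the assay (the limit of > 1000000000 nM in this assay, at which 1 of the 3 values shown sits). Going by the values given here, the only measured step, an at least 1.7-fold lower number from compound 1 to compound 2 (0.25 log units; that floor lies within the scatter), has a floor that itself lies within the scatter.

Compound 4 `CCS(=O)(=O)N[C@@H]1C=C[C@@H](OC(C)=O)[C@@H](COC(C)=O)O1` keeps every atom of compound 3; the change is the two compounds have the same atoms and bonds and differ only in configuration as drawn: 1 of 3 stereo elements differ; a stereocentre at a saturated ring carbon is drawn S in compound 3 and R in compound 4. No measured step here changes a configuration, so nothing shown bears directly on this move; the one measured step was small and concerned a different kind of change. The expected step of a 1.1-fold higher number from compound 3 to compound 4 (0.03 log units; within the scatter) is therefore none beyond the scatter. Compound 4 is estimated at 300000000 nM, with a range from 100000000 nM to 1000000000 nM.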

Compound 4, half-maximal inhibitory concentration: > 1000000000 nM
Compound 4 ended at the assay's limit; the forecaster's own chance of this, stated with the estimate: 30%; middle value at least 3.3-fold (0.52 log units) from the limit.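

In this assay, changing one stereocentre at a saturated ring carbon from S to R gives an at least 3.5-fold higher number from compound 3 to compound 4 (0.55 log units; beyond the scatter), the only step shown whose size clears the scatter, and no atom or bond differs: the fact that compounds 3 and 4 differ only in the configuration as drawn. The value of compound 4 is a limit of the assay and not a number: the limit of > 1000000000 nM in this assay, at which 2 of the 4 values shown sit. The other readable comparison, an at least 1.7-fold higher number from compound 2 to compound 4 (0.25 log units; that floor lies within the scatter), swaps the group on the sulfonyl sulfur, while the step joining the two limits cannot be read.

This flip rests on a single pair of compounds, so it shows no general pattern. Going by these compounds, whether a longer chain such as butyl on the sulfonyl sulfur would respond to the same flip stays open, as does the true value of compound 4.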